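This account rests on a few compounds, and the source may have more. Where it says the series, first, only, none or still open, it means among the compounds named here.

Measured so far in a functional assay on A549 cells (Homo sapiens) for cytotoxicity, read by MTT assay, with a stated time of 48 h; a higher number here means a weaker inhibitor, a lower number a stronger inhibitor:
compound 1 `COc1cc(NC(=O)n2cc(-c3ccc(O)cc3)n(-c3cc(OC)c(OC)c(OC)c3)c2=O)cc(OC)c1OC` gives 2500 nM
compound 2 `COc1cc(-n2c(-c3ccccc3)cn(C(C)=O)c2=O)cc(OC)c1OC` gives > 50000 nM (a limit, not a number)

Compound 2 stands at > 50000 nM in this assay and this value is a limit of the assay. Among the compounds with values here, compound 1 is the only one of the two with a measured number (2500 nM), and no measured step connects the two compounds through a single change.

Compound 3 `COc1cc(-n2c(-c3ccc(Br)cc3)cn(C(C)=O)c2=O)cc(OC)c1OC` is compound 2 with phenyl changed to 4-bromophenyl, that is, bromo in place of hydrogen on an aromatic carbon of a six-membered aromatic ring of carbon only, para to a large group. The counted difference reads bromo in place of hydrogen on an aromatic carbon for this change.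

Within the data shown here, the series offers no measured example of this change, so the expectation is a cautious one. In this assay only a small step towards stronger inhibition is expected, or none beyond the scatter, and a second result at the limit would be no surprise. The estimate is an at least 1.2-fold lower number from compound 2 to compound 3 (0.09 log units; that floor lies within the scatter) and it is expected to stay small. Compound 3 is expected at 40000 nM with an estimated range from 15000 nM to 60000 nM in this readout.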

Compound 3, half-maximal inhibitory concentration: 1300 nM
For compound 3 the middle estimate is 31-fold (1.49 log units) above the measured one; measured number outside the range, below it.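

In this assay, bromo in place of hydrogen on an aromatic carbon of a six-membered aromatic ring of carbon only, para to a large group, gives an at least 38-fold lower number from compound 2 to compound 3 (1.58 log units; beyond the scatter). Within the data shown here, this is the only measured change at this position, and it shows that the position is sensitive: one added heavy atom is enough to give a measured number, with compound 3 at 1300 nM. For compound 2 the value of > 50000 nM is a limit of the assay, so the step is a floor and its full size remains unknown: the limit of > 50000 nM in this assay, at which 1 of the 3 values shown sits.

With bromo as the only substituent shown at this position, it remains open whether the effect is specific to bromo or would also appear with fluoro, an amine or a carboxylic acid in the same place. As far as these compounds go, compound 1 differs from both compound 2 and compound 3 in more than one place, so the step cannot be read across to it, and whether bromo would have the same effect on that compound also remains open.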